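Three Esters Measured, a Fourth Awaited

The source may hold more compounds than are shown below. What is called first, only, known or untested is meant among the compounds shown, and "the series" means these compounds.

Three esters of a shared core have been measured in a functional assay on RAW264.7 cells (Mus musculus) for inhibition, read by ELISA, with a stated time of 24 h; on this read-out lower numbers stand for an effect already at smaller amounts and higher numbers for an effect only at larger amounts of compound. Compound 1 `CC/C=C\CC1C(=O)C=CC1CC(=O)OC` gives 19000 nM, compound 2 `CC/C=C\C[C@H]1C(=O)C=C[C@H]1CC(=O)OCc1ccccc1` gives 20000 nM, and compound 3 `CC/C=C\C[C@H]1C(=O)C=C[C@H]1CC(=O)Oc1ccccc1OC` gives 32000 nM. The numbers of compound 1 and of compound 3 both lie within the usual scatter of the number of compound 2, so the three esters cannot be told apart on what has been measured. Compound 4 `CC/C=C\C[C@H]1C(=O)C=C[C@H]1CC(=O)OCCOCCOC` has not yet been measured. It differs from compound 2 by (2-methoxyethoxy)methyl in place of phenyl on a saturated chain carbon bound to an oxygen next to a carbonyl group. Because compound 2 gives 20000 nM and neither compound 1 nor compound 3 stands apart from it beyond the scatter, the step of a 1.1-fold higher number from compound 2 to compound 4 (0.04 log units; within the scatter) is expected to stay within the scatter. Compound 4 is therefore estimated at 22000 nM in this assay, within a range from 10000 nM to 50000 nM.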

Compound 4, half-maximal effective concentration: 33000 nM
For compound 4 the middle estimate is 1.5-fold (0.18 log units) below the measured one; low and high end bracket the measured number.
By their numbers in this assay, from the lowest: compounds 1, 2, 3 and 4 (each within the scatter of the next).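

In this assay, (2-methoxyethoxy)methyl in place of phenyl on a saturated chain carbon bound to an oxygen next to a carbonyl group gives a 1.7-fold higher number from compound 2 to compound 4 (0.22 log units; within the scatter) and so does not move the number beyond the scatter. At this position, then, the six-membered aromatic ring can give way to a chain with no ring and 2 hydrogen-bond acceptors without a change that can be read. Nothing at hand bears on this result.

On these data alone, whether an amine, a carboxylic acid or a longer chain in this place would give a number beyond the scatter of compound 2 remains open.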